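The compounds below may be only part of what the source reports. "The series", "measured", "known", "first", "only" and "open" are said of these compounds alone.

Measured compounds:
- compound 1 `O=C(OCCCc1ccccc1)c1cc(-n2cc(-c3cccc(O)c3)nn2)ccc1O` gives 9% in a functional assay on CCRF-CEM cells (Homo sapiens) for inhibition, read by MTT assay, with a stated time of 2 days, tested at 10 uM; a lower number here means less inhibition, a higher number more inhibition at the concentration tested (going by the name of the read-out)
- compound 2 `COc1ccc(-c2cn(-c3ccc(O)c(C(=O)O)c3)nn2)cc1` gives 9% in this assay
- compound 3 `COc1ccccc1-c1cn(-c2ccc(O)c(C(=O)OCCCc3ccccc3)c2)nn1` gives 4% in this assay

Compound 3 has the lowest of the three numbers, yet the step of a number 5 percentage points lower from compound 1 to compound 3 (within the scatter) is within the scatter, and the values of compound 2 and compound 3 also sit within the scatter of each other, so none of the three can be set apart. Compound 4 `COc1ccc(-c2cn(-c3ccc(O)c(C(=O)OCCCc4ccccc4)c3)nn2)cc1` differs from compound 3 by 4-methoxyphenyl in place of 2-methoxyphenyl on an aromatic carbon. Among the compounds with values here, the only measured step that swaps the group on that carbon, a number 5 percentage points lower from compound 1 to compound 3 (within the scatter), produced no change beyond the scatter, and no measured pair swaps 2-methoxyphenyl for 4-methoxyphenyl, so no step beyond the scatter is expected in this assay. Compound 4 is therefore estimated at 6%, between -6% and 18%, a step of a number 2 percentage points higher from compound 3 to compound 4 (within the scatter).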

Compound 4, a percentage reported as inhibition, at one concentration (the size of the read-out at that concentration, not a potency): 5%
Estimate against measurement, compound 4: 1 percentage points above; low and high end bracket the measured number.
By their numbers in this assay, from the lowest: compounds 3, 4, 1 and 2 (each within the scatter of the next).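

Swapping 2-methoxyphenyl for 4-methoxyphenyl on the aromatic carbon of the five-membered ring gives a number 1 percentage points higher from compound 3 to compound 4 (within the scatter) in this assay, so shifting the methoxy group around that phenyl ring does not change the read-out measurably. The same holds for 4-methoxyphenyl in place of 3-hydroxyphenyl, with a number 4 percentage points lower from compound 1 to compound 4 (within the scatter), and for 3-phenylpropyl in place of hydrogen on the oxygen next to a carbonyl group, with a number 4 percentage points lower from compound 2 to compound 4 (within the scatter). From the compounds shown here alone, whether an aminophenyl group on that carbon, or a chain longer than 3-phenylpropyl on that oxygen, would give a step beyond the scatter stays open. Nothing available offers an explanation for these readings.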